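Chloro for hydrogen on the benzyl ether of compound 3

A few compounds are considered here, and "the series" means these few. Any claim that something is new, unique, unknown or untested is made for them only; others in the source may bear on it.

Measured compounds:
Compound 1 `COc1ccc(OCCOc2ccc3[nH]c(=O)n(C(C)C)c3c2)cc1` gives 15.5% in an assay on cells for inhibition of Amine oxidase [flavin-containing] B (Homo sapiens), read by fluorescence, with stated times of 30 min and 15 min, tested at 1 uM; a higher number here means more inhibition at the concentration tested (going by the name of the read-out), a lower number less inhibition.
Compound 2 `CC(C)C1C(=O)Nc2ccc(OCc3cccc(F)c3)cc21` gives 12.7% in this assay.
Compound 3 `Cn1c(=O)[nH]c2cc(OCc3ccccc3)ccc21` was reported as "not active" (no number reported) in this assay, with no number given.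

Compound 3 therefore stands below the two compounds that did return a number: compound 1 and compound 2 each show a low percentage of inhibition, while compound 3 shows so little that only a qualitative statement was made. Compound 4 `Cn1c(=O)[nH]c2cc(OCc3cccc(Cl)c3)ccc21` differs from compound 3 by one change: chloro in place of hydrogen on an aromatic carbon. Within the data shown here, no step between measured compounds tells how much this kind of exchange moves the read-out, so the expectation rests on the neighbouring compounds alone. Since compound 2, which also carries a halogen on its benzyl ether, gives 12.7%, a step upward from compound 3 that stays within the scatter is expected in this assay, with a real chance that compound 4 is again reported only as not active. Compound 4 is estimated to give 10%, expected to lie between 0% and 25%.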

Compound 4, a percentage reported as inhibition, at one concentration (the size of the read-out at that concentration, not a potency): 23.4%
The estimate for compound 4 lay 13.4 percentage points below the measured number, within the range that was stated.
By their numbers in this assay, from the lowest: compounds 2, 1 and 4 (each within the scatter of the next, the first and the last beyond it).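

Among these compounds, compound 3 was reported only as not active in this assay, with no number, so no step from it to compound 4 can be read. What chloro for hydrogen does to the inhibition stays open, and no evidence shown bears on this result.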